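This account rests on a few compounds, and the source may have more. Where it says the series, first, only, none or still open, it means among the compounds named here.

Compound 1 `CCOC(=O)C1=Cc2ccccc2OC1(OCc1cn(CC(=O)Nc2cccc(Cl)c2)nn1)C(F)(F)F`: 11600 nM
Compound 2 `CCOC(=O)C1=Cc2ccccc2OC1(OCc1cc(-c2ccc3ccccc3c2)no1)C(F)(F)F`: 65400 nM

Among the measured compounds shown here, in a functional assay on MCF7 cells (Homo sapiens) for inhibition, read by MTT assay, with a stated time of 24 h (a higher number here means a weaker inhibitor, a lower number a stronger inhibitor), compound 1 gives 11600 nM, the lower of the two numbers measured so far. Compound 2 gives 65400 nM, a higher number that lies beyond the scatter. Compound 3 `CCOC(=O)C1=Cc2ccccc2OC1(OCc1cn(CC(=O)Nc2cccc(F)c2)nn1)C(F)(F)F` has not been measured. It differs from compound 1 in a single place: fluoro in place of chloro on an aromatic carbon. For the measured compounds named here, no measured pair shows this change, so the step from compound 1 to compound 3 is expected to be small, a 1.3-fold higher number from compound 1 to compound 3 (0.11 log units; within the scatter), and may not reach beyond the scatter. For compound 3 the estimate in this assay is 15000 nM, with a range from 5000 nM to 45000 nM.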

Compound 3, half-maximal inhibitory concentration: > 150000 nM
Compound 3 was reported as a limit (the forecaster's own chance of this, stated with the estimate: 15%); middle value at least 10-fold (1.00 log units) away from the limit.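

In this assay, among the compounds shown here, the single change from 3-chlorophenyl to 3-fluorophenyl gives an at least 12-fold higher number from compound 1 to compound 3 (1.11 log units; beyond the scatter) and so is the first step here that isolates this position. The value of compound 3 is a limit of the assay and not a number: the limit of > 150000 nM in this assay, at which 1 of the 3 values shown sits. Even so, the step shows that the number at this aromatic carbon depends strongly on which halogen is present, something compound 1 and compound 2 could not show.

From the compounds shown here alone, whether bromo, methyl or methoxy at this position would keep the number close to that of compound 1 remains open. Going by these compounds, the full size of the step also remains open.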